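The compounds below may be only part of what the source reports. "The series", "measured", "known", "first", "only" and "open" are said of these compounds alone.

Measured compounds in this set:
compound 1 `CC1(OC(=O)N2CC3COCC(C2)C3Oc2ncnc(Nc3ccc(F)cc3F)c2F)CC1`: 15 nM
compound 2 `N#Cc1ccc(Oc2ncnc(OC3C4COCC3CN(c3ncc(F)cn3)C4)c2C2CC2)c(Cl)c1`: 212 nM
compound 3 `CCC1(OC(=O)N2CC3COCC(C2)C3Oc2ncnc(Nc3ccc(C#N)cc3F)c2F)CC1`: 6 nM

In a functional assay on HEK293 cells for agonist activity at Glucose-dependent insulinotropic receptor (Homo sapiens), read by cAMP accumulation, with a stated time of 30 min (on this read-out lower numbers stand for an effect already at smaller amounts and higher numbers for an effect only at larger amounts of compound), compound 1 gives 15 nM, the second highest of the three numbers. Compound 3 sits nearest, at a lower number that lies beyond the usual scatter; compound 2 stands furthest, at a higher number, also beyond the scatter. No two of these compounds differ in a single place, so no single-point step can be read from the measured set.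

Compound 4 `CC1(OC(=O)N2CC3COCC(C2)C3Oc2ncnc(Nc3cccnc3Cl)c2F)CC1` has not yet been measured in this assay. It differs from compound 1 by 2-chloropyridin-3-yl in place of 2,4-difluorophenyl on a nitrogen on an aromatic ring. For the measured compounds named here, nothing among the measured compounds isolates a change of this kind on that nitrogen; compound 3 shows only that a different group there, together with other changes, keeps the number low. The expected step from compound 1 to compound 4 is a 2.0-fold higher number from compound 1 to compound 4 (0.30 log units; within the scatter), a modest rise in number that may well stay within the scatter. Compound 4 is therefore expected to give 30 nM, with a range from 8 nM to 120 nM.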

Compound 4, half-maximal effective concentration: 17 nM
For compound 4 the middle estimate is 1.8-fold (0.25 log units) above the measured one, within the range that was stated.
By their numbers in this assay, from the lowest: compound 3; then compounds 1 and 4 (each within the scatter of the next); then compound 2.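

In this assay, for the compounds shown here, 2-chloropyridin-3-yl in place of 2,4-difluorophenyl on the nitrogen gives a 1.1-fold higher number from compound 1 to compound 4 (0.05 log units; within the scatter), the first single-place step. At this position, an aromatic ring with one hetero atom and a chlorine therefore stands level with a carbon-only aromatic ring bearing two fluorines, and the hydrogen-bond acceptor that enters brings no step beyond the scatter. No measurement at hand offers an explanation for this result.

The ring nitrogen and the chlorine enter together, so their separate contributions cannot be read from compound 4. From the compounds shown here alone, it also remains open whether this nitrogen accommodates a non-aromatic group such as cyclohexyl, or an aromatic ring carrying a methoxy group or a carboxylic acid.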